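The source may report more compounds than this note shows. Statements on the series, on what has been measured and on what is new or still open speak of the compounds shown alone.

Measured so far in a functional assay on P388 cells (Mus musculus) for cytotoxicity; on this read-out lower numbers stand for an effect already at smaller amounts and higher numbers for an effect only at larger amounts of compound:
- Compound 1 `CCOc1cc(-c2ccccc2)nc2ccccc12` gives 6 ug/mL as its value.
- Compound 2 `CC(C)Oc1cc(-c2ccccc2)nc2ccccc12` gives > 10 ug/mL as a limit.
- Compound 3 `CCCOc1cc(-c2ccccc2)nc2ccccc12` gives 6.9 ug/mL as its value.

Among the compounds with values here, compound 3 has only one numeric neighbour, and the two are not separated, with a 1.2-fold higher number from compound 1 to compound 3 (0.06 log units; within the scatter) in the data. Compound 4 (`CCCCOc1cc(-c2ccccc2)nc2ccccc12`) takes propyl to butyl, with methyl in place of hydrogen on a saturated chain carbon, three bonds along the chain from an oxygen on an aromatic ring. Within the data shown here, the closest precedent is the ethyl to propyl change, a 1.2-fold higher number from compound 1 to compound 3 (0.06 log units; within the scatter) in size. The branching step, an at least 1.6-fold higher number from compound 1 to compound 2 (0.22 log units; that floor lies within the scatter) as measured, bears less directly. The expected change is a 1.1-fold higher number from compound 3 to compound 4 (0.04 log units; within the scatter) and so none beyond the scatter. Compound 4 is estimated at 7.5 ug/mL with a range from 3.5 ug/mL to 15 ug/mL expected.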

Compound 4, half-maximal effective concentration: > 10 ug/mL
Compound 4: a limit, no number (the forecaster's own chance of this, stated with the estimate: 25%); middle value at least 1.3-fold (0.12 log units) away from the limit.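

In this assay compound 4 gives a limit and not a number, so a straight chain, here butyl, now also ends where the branched compound 2 does: the limit of > 10 ug/mL in this assay, at which 2 of the 4 values shown sit. Against the shorter chains the change reads as an at least 1.4-fold higher number from compound 3 to compound 4 (0.16 log units; that floor lies within the scatter) and an at least 1.6-fold higher number from compound 1 to compound 4 (0.22 log units; that floor lies within the scatter), so no loss beyond the scatter can be claimed. The step between the two limits cannot be read.

From the compounds shown here alone, how far the true value of compound 4 lies from compound 3 stays open. So does whether a longer chain, or an amine at the end of the butyl chain, would give a number at all.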